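This account rests on a few compounds, and the source may have more. Where it says the series, first, only, none or still open, it means among the compounds named here.

In a functional assay on HEK293 cells for agonist activity at Neuronal acetylcholine receptor; alpha4/beta2 (Homo sapiens), read by FLIPR (on this read-out higher numbers stand for an effect only at larger amounts of compound and lower numbers for an effect already at smaller amounts), compound 1 `Brc1cncc(N2CC[C@H]3CN[C@H]3C2)c1` gives 150 nM, the highest of the two numbers recorded so far. Compound 2 `Brc1cc(N2CC[C@H]3CN[C@H]3C2)cnc1Br` gives 7.8 nM in this assay, the step of a 19-fold lower number from compound 1 to compound 2 (1.28 log units; beyond the scatter) arising from bromo in place of hydrogen on an aromatic carbon. Compound 3 `CCOc1cncc(N2CC[C@H]3CN[C@H]3C2)c1` has not yet been measured and differs from compound 1 as follows: ethoxy in place of bromo on an aromatic carbon. For the measured compounds named here, the only measured step adds a second bromo and keeps the original one, so it does not speak directly to exchanging that bromo for ethoxy; no measured pair shows what ethoxy does at this carbon. Since both known compounds carry bromo there, the step of a 2.0-fold higher number from compound 1 to compound 3 (0.30 log units; within the scatter) is expected to be modest, toward a somewhat higher number, with wide uncertainty. Compound 3 is estimated at 300 nM, in a range from 80 nM to 1200 nM.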

Compound 3, half-maximal effective concentration: 620 nM
Estimate against measurement, compound 3: 2.1-fold (0.32 log units) below; the range from low to high includes it.
By their numbers in this assay, from the lowest: compound 2; then compound 1; then compound 3.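

For the compounds shown here, exchanging bromo for ethoxy on this aromatic carbon, two atoms from the ring nitrogen, gives a 4.1-fold higher number from compound 1 to compound 3 (0.62 log units; beyond the scatter) in this assay, the first reading of a change at this carbon itself, since the earlier step concerned another aromatic carbon. The number thus responds to what sits at this place, with the entering ethoxy having more heavy atoms than bromo and one hydrogen-bond acceptor where bromo has none. That single exchange cannot separate these differences, and no measurement at hand explains the step.

On these data alone, whether methoxy, an amine or a chain longer than ethoxy at this carbon would give a number closer to that of compound 1 remains open. Also open, as far as these compounds go, is how ethoxy would fare alongside the second bromo of compound 2.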